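The source may report more compounds than this note shows. Statements on the series, on what has been measured and on what is new or still open speak of the compounds shown alone.

The series shares one core carrying a fluorophenoxyphenyl arm, and differs only at the second exocyclic carbon. In a functional assay on NCI-H460 cells (Homo sapiens) for cytotoxicity, read by MTT assay, with a stated time of 72 h (a lower number here means a stronger inhibitor, a higher number a weaker inhibitor), compound 1, `Cc1[nH]cnc1/C=c1\[nH]c(=O)/c(=C/c2cccc(Oc3ccc(F)cc3)c2)[nH]c1=O`, gives 47.6 nM. Among the measured compounds shown here, compound 2, `O=c1[nH]/c(=C\c2ccco2)c(=O)[nH]/c1=C\c1cccc(Oc2ccc(F)cc2)c1`, gives 155 nM in this assay, which is the higher of the two numbers recorded so far; the only neighbouring step, a 3.3-fold higher number from compound 1 to compound 2 (0.51 log units; beyond the scatter), is the one that separates it from compound 1.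

Compound 3, `O=c1[nH]/c(=C\c2ccc([N+](=O)[O-])o2)c(=O)[nH]/c1=C\c1cccc(Oc2ccc(F)cc2)c1`, is the next variation. Its difference from compound 2 is nitro in place of hydrogen on an aromatic carbon. For the measured compounds named here, the single measured step, a 3.3-fold higher number from compound 1 to compound 2 (0.51 log units; beyond the scatter), concerns the exchange of the whole five-membered ring for another ring and therefore does not bear directly on a substituent added to the furan-2-yl ring already present; no measured pair shows what a nitro group does on this core. With nothing to point either way, the expectation is a change within the scatter, written as a 1.4-fold lower number from compound 2 to compound 3 (0.15 log units; within the scatter). The estimate for compound 3 in this assay is therefore 110 nM, with a range from 35 nM to 350 nM.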

Compound 3, half-maximal inhibitory concentration: > 1000 nM
Compound 3 gave a limit, no number (the forecaster's own chance of this, stated with the estimate: 2%); middle value at least 9.0-fold (0.95 log units) from the limit.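

In this assay compound 3 gives a limit of the assay and not a number: the limit of > 1000 nM in this assay, at which 1 of the 3 values shown sits.

Even so, the step can be read in one direction: placing nitro on an aromatic carbon of the five-membered ring, next to the ring oxygen, gives an at least 6.4-fold higher number from compound 2 to compound 3 (0.80 log units; beyond the scatter). The earlier compounds shown here differed only by exchanging one whole ring for another, whereas this pair shows that a single added group on the furan-2-yl ring can by itself move the number beyond the scatter. The change from 5-methyl-1H-imidazol-4-yl to 5-nitrofuran-2-yl gives an at least 21-fold higher number from compound 1 to compound 3 (1.32 log units; beyond the scatter), a large step that runs the same way as a 3.3-fold higher number from compound 1 to compound 2 (0.51 log units; beyond the scatter), so among these three compounds the 5-methyl-1H-imidazol-4-yl group carries the lowest number.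

Nitro is the only substituent shown on the furan-2-yl ring, so it remains open whether this result belongs to nitro itself or would follow from any group at that carbon. A methyl group, an amine or a carboxylic acid at the same place would separate those two readings, and nitro on a different ring at this position would show whether the step holds beyond the furan-2-yl ring.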